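Aryl variation on the amide pyridine: a limit-bound series

A few compounds are considered here, and "the series" means these few. Any claim that something is new, unique, unknown or untested is made for them only; others in the source may bear on it.

Compound 1 `COc1ccc(-c2ccc(C(=O)Nc3ccc(Oc4ccnc5[nH]ccc45)cc3)nc2)cc1`, compound 2 `Cc1ccc(-c2ccnc(C(=O)Nc3ccc(Oc4ccnc5[nH]ccc45)cc3)c2)cc1` and compound 3 `O=C(Nc1ccc(Oc2ccnc3[nH]ccc23)cc1)c1cc(-c2ccc(C(F)(F)F)cc2)ccn1` carry the same shared core and differ only in the aryl group on the pyridine. In a functional assay on MCF7 cells (Homo sapiens) for cytotoxicity, read by MTT assay, with a stated time of 72 h (on this read-out lower numbers stand for stronger inhibition and higher numbers for weaker inhibition), compound 1 gives > 10000 nM, which is a limit of the assay and not a number. In this assay compound 2 gives > 10000 nM, again a limit. In this assay compound 3 gives > 10000 nM, also a limit, so compound 3 stands at the ceiling of the assay with no number of its own. This is summed up by the limit of > 10000 nM in this assay, at which 3 of the 3 values shown sit. The step that the two limits leave unreadable from compound 2 to compound 3 is therefore not readable in either size or direction.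

Compound 4 `Cc1cccc(-c2ccnc(C(=O)Nc3ccc(Oc4ccnc5[nH]ccc45)cc3)c2)c1` differs from compound 3 in one place: 3-methylphenyl in place of 4-(trifluoromethyl)phenyl on an aromatic carbon. Within the data shown here, no measured step speaks readably to this change, the only neighbouring step being the unreadable one from compound 2 to compound 3. Among the measured compounds shown here, with every value so far sitting at the limit, compound 4 is expected to give a limit as well in this assay, around 15000 nM with a range of 7000 nM to 40000 nM. The estimated step that the limit leaves unreadable from compound 3 to compound 4 is expected to be none beyond the scatter.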

Compound 4, half-maximal inhibitory concentration: 7470 nM
Beside the measured number, compound 4's estimate is 2.0-fold (0.30 log units) above it; measured number inside the range.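

Working notes: the aryl position opposite the ring nitrogen now has its first value that is a number, as in this assay compound 4 gives 7470 nM. 3-Methylphenyl in place of 4-(trifluoromethyl)phenyl gives an at least 1.3-fold lower number from compound 3 to compound 4 (0.12 log units; that floor lies within the scatter), and 3-methylphenyl in place of 4-methylphenyl gives an at least 1.3-fold lower number from compound 2 to compound 4 (0.12 log units; that floor lies within the scatter). Both are floors only, so neither change is shown to act beyond the scatter, and the true size of each step stays unknown, with the other values offering no number for comparison: the limit of > 10000 nM in this assay, at which 3 of the 4 values shown sit.

Open, on these data alone, is what an amine or a carboxylic acid on this phenyl ring would give in this assay. Also open, as far as these compounds go, is whether a longer chain in place of the methyl of compound 4 would shift the number in this assay.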